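The source may hold more compounds than are shown below. What is called first, only, known or untested is meant among the compounds shown, and "the series" means these compounds.

Compound 2 `COc1ccc(C(=O)/C=C/c2cc(-c3cc(OC)c(OC)c(OC)c3)n[nH]2)cc1OC` gives 70% in a functional assay on MDA-MB-435 cells (Homo sapiens) for cytotoxicity, read by sulforhodamine B assay, with a stated time of 48 h, tested at 1 uM (on this read-out higher numbers stand for a weaker effect at the one concentration tested and lower numbers for a stronger effect), the lower of the two numbers measured. Compound 1 `COc1cc(-c2cc(/C=C/C(=O)c3ccc(Cl)c(Cl)c3)[nH]n2)cc(OC)c1OC` gives 90%, and the step of a number 20 percentage points lower from compound 1 to compound 2 (beyond the scatter) is the only one measured; it changed the same ring that is altered here. Compound 3 `COc1ccc(C(=O)/C=C/c2cc(-c3cc(OC)c(OC)c(OC)c3)n[nH]2)cc1` differs from compound 2 by hydrogen in place of methoxy on an aromatic carbon. Going by the values given here, no measured step removes a methoxy, so the direction is uncertain and only a small change is expected. Compound 3 is estimated at 75%, between 55% and 95%, an expected step of a number 5 percentage points higher from compound 2 to compound 3 (within the scatter).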

Compound 3, a percentage reported as activity, at one concentration (the size of the read-out at that concentration, not a potency): 92%
Compound 3: the middle estimate sits 17 percentage points below what was measured; the measured number falls inside the stated range.
By their numbers in this assay, from the lowest: compound 2; then compounds 1 and 3 (each within the scatter of the next).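

Taking this methoxy off the ring, so that 3,4-dimethoxyphenyl becomes 4-methoxyphenyl, is not a neutral change in this assay: the step is a number 22 percentage points higher from compound 2 to compound 3 (beyond the scatter), so the stronger effect of compound 2 is lost. With the single methoxy, the step is a number 2 percentage points higher from compound 1 to compound 3 (within the scatter), so this ring performs no differently from the 3,4-dichlorophenyl ring. Nothing available explains why this methoxy matters. Going by these compounds, whether a hydroxyl, a fluorine or an amine at this place would keep the effect of the methoxy remains open.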